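Step from compound 2 to compound 3 in the HEK293 assay

The source may hold more compounds than are shown below. What is called first, only, known or untested is meant among the compounds shown, and "the series" means these compounds.

Measured so far:
compound 1 `COc1ccc(-c2cc(C(=O)/C=C/c3ccccc3)nc3cc(-c4ccccc4)nn23)cc1OC`, 64100 nM
compound 2 `COc1ccc(-c2cc(C(=O)/C=C/c3ccc(Cl)cc3)nc3cc(-c4ccccc4)nn23)cc1OC`, 39100 nM

The series is followed in an ADME assay on HEK293 cells (Homo sapiens) for antiproliferative activity, read by MTT assay, with a stated time of 24 h; a higher number here means a weaker inhibitor, a lower number a stronger inhibitor. Compound 1 `COc1ccc(-c2cc(C(=O)/C=C/c3ccccc3)nc3cc(-c4ccccc4)nn23)cc1OC` gives 64100 nM in this assay. Among the measured compounds shown here, compound 2 `COc1ccc(-c2cc(C(=O)/C=C/c3ccc(Cl)cc3)nc3cc(-c4ccccc4)nn23)cc1OC` gives 39100 nM in this assay, and stands at the lowest of the two numbers so far, with compound 1 as its only neighbour. For the measured compounds named here, the one measured step, a 1.6-fold lower number from compound 1 to compound 2 (0.21 log units; within the scatter), is within the scatter, so nothing beyond the scatter separates the two measured compounds.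

Compound 3 `COc1ccc(-c2cc(C(=O)/C=C/c3cc(OC)c(OC)c(OC)c3)nc3cc(-c4ccccc4)nn23)cc1OC` has not yet been measured. It differs from compound 2 in one place: 3,4,5-trimethoxyphenyl in place of 4-chlorophenyl on a double-bonded chain carbon bound to a double-bonded chain carbon. Going by the values given here, the only measured step concerns a chloro in place of hydrogen on the same aromatic ring and does not speak to the entering 3,4,5-trimethoxyphenyl. The numbers give no basis for expecting a step beyond the scatter in this assay. The step of a 1.1-fold lower number from compound 2 to compound 3 (0.05 log units; within the scatter) is therefore expected to be small, with a wide range. For compound 3 the estimate in this assay is 35000 nM, between 12000 nM and 110000 nM.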

Compound 3, half-maximal inhibitory concentration: 46800 nM
For compound 3 the middle estimate is 1.3-fold (0.13 log units) below the measured one; measured number inside the range.
By their numbers in this assay, from the lowest: compounds 2, 3 and 1 (each within the scatter of the next).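

In this assay the exchange at the double-bonded chain carbon bound to a double-bonded chain carbon gives a 1.2-fold higher number from compound 2 to compound 3 (0.08 log units; within the scatter) on going from 4-chlorophenyl, with 7 heavy atoms and 0 hydrogen-bond acceptors, to 3,4,5-trimethoxyphenyl, with 12 heavy atoms and 3 hydrogen-bond acceptors. Measured against the plain phenyl, the same entering group gives a 1.4-fold lower number from compound 1 to compound 3 (0.14 log units; within the scatter) and so adds a second comparison at this place, which now holds phenyl, 4-chlorophenyl and 3,4,5-trimethoxyphenyl with all three compounds within the scatter of one another, despite the larger change in heavy atoms and acceptors than in the earlier chloro step. No accompanying measurement bears on this outcome.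

From the compounds shown here alone, whether any group at this place can move the number beyond the scatter stays open, for example an aromatic ring carrying an amine or a carboxylic acid, or a longer chain in place of the ring. The compounds shown also keep the 3,4-dimethoxyphenyl and phenyl groups on the shared core unchanged, so the effect of replacing either of them, for instance with a pyridine ring, remains unknown in this series.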